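The source may report more compounds than this note shows. Statements on the series, on what has been measured and on what is new or still open speak of the compounds shown alone.

Measured in a functional assay on A549 cells (Homo sapiens) for cytotoxicity; a higher number here means a weaker inhibitor, a lower number a stronger inhibitor:
- Compound 1 `C=C/C=C\[C@H](C)[C@H](OC(N)=O)[C@@H](C)[C@H](O)[C@@H](C)C/C(C)=C\[C@H](C)[C@@H](O)[C@@H](C)/C=C\CCc1cccc(O)c1C`: 910 nM
- Compound 2 `C=C/C=C\[C@H](C)[C@H](OC(N)=O)[C@@H](C)[C@H](O)[C@@H](C)C/C(C)=C\[C@H](C)[C@@H](O)[C@@H](C)/C=C\CCc1ccc(C)c(O)c1`: 4000 nM
- Compound 3 `C=C/C=C\[C@H](C)[C@H](OC(N)=O)[C@@H](C)[C@H](O)[C@@H](C)C/C(C)=C\[C@H](C)[C@@H](O)[C@@H](C)/C=C\CCc1cccc(Cl)c1`: 580 nM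

Compound 3 stands at the low end of these numbers, though not apart from every neighbour. The nearer gap is a 1.6-fold lower number from compound 1 to compound 3 (0.20 log units; within the scatter), and the wider one is a 6.9-fold lower number from compound 2 to compound 3 (0.84 log units; beyond the scatter).

Compound 4 `C=C/C=C\[C@H](C)[C@H](OC(N)=O)[C@@H](C)[C@H](O)[C@@H](C)C/C(C)=C\[C@H](C)[C@@H](O)[C@@H](C)/C=C\CCc1cc(O)cc(O)c1` has not yet been measured. It differs from compound 3 by 3,5-dihydroxyphenyl in place of 3-chlorophenyl on a saturated chain carbon, two bonds along the chain from a double-bonded chain carbon.

Among the measured compounds shown here, no measured step makes this exact exchange, and no measured compound carries two hydroxy groups on the ring. The nearest evidence is the pair of steps above, which link 3-chlorophenyl with a ring bearing one hydroxy group. One stays within the scatter and the other is modest. The shift between the two hydroxy-methylphenyl compounds, a 4.4-fold higher number from compound 1 to compound 2 (0.64 log units; beyond the scatter), shows that the outcome varies with the ring's substitution.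

A modest step to a higher number is therefore expected in this assay, with a wide margin. The expected step is a 3.1-fold higher number from compound 3 to compound 4 (0.49 log units; beyond the scatter). The estimate for compound 4 is 1800 nM, with an estimated range of 550 nM to 6000 nM.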

Compound 4, half-maximal inhibitory concentration: 310 nM
Beside the measured number, compound 4's estimate is 5.8-fold (0.76 log units) above it; the whole stated range lies above it.
By their numbers in this assay, from the lowest: compounds 4, 3 and 1 (each within the scatter of the next, the first and the last beyond it); then compound 2.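

In this assay, the exchange of 3-chlorophenyl for 3,5-dihydroxyphenyl on this saturated chain carbon gives no difference that the assay can separate (a 1.9-fold lower number from compound 3 to compound 4 (0.27 log units; within the scatter)), so the position accepts a ring with hydroxy groups and no chlorine at all. The earlier compounds shown here left open whether a hydroxy-bearing ring would stay in this range, since compound 1 did but compound 2 did not. Compound 4 now sets the dihydroxy ring clearly apart from both hydroxy-methylphenyl rings (a 13-fold lower number from compound 2 to compound 4 (1.11 log units; beyond the scatter); a 2.9-fold lower number from compound 1 to compound 4 (0.47 log units; beyond the scatter)), which shows that the presence of a hydroxy group does not alone fix the number and that compound 1 and compound 2 differ from compound 4 by more than the count of such groups. Nothing given here accounts for these differences.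

The compounds shown leave open how a plain 3-hydroxyphenyl ring, carrying no methyl, or a 3,5-dichlorophenyl ring would compare at this position. They also leave open whether an amine or a carboxylic acid on the ring, or a longer chain leading to it, would keep the number in the range of compound 3 and compound 4.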